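Core ethers with varied substituents on the aromatic nitrogen

The source may hold more compounds than are shown below. What is called first, only, known or untested is meant among the compounds shown, and "the series" means these compounds.

Compound 2 `COC(=O)Cn1cc(CO[C@H]2CC(=O)[C@@H]3OC[C@H]2O3)nn1` holds the lowest of the two numbers in hand: in a functional assay on MDA-MB-231 cells (Homo sapiens) for cytotoxicity, read by MTT assay, with a stated time of 48 h (on this read-out higher numbers stand for weaker inhibition and lower numbers for stronger inhibition), compound 2 gives 21300 nM. Compound 3 `O=C1C[C@H](OCc2cn(-c3ccccc3)nn2)[C@H]2CO[C@@H]1O2`, which bears phenyl in place of (methoxycarbonyl)methyl on an aromatic nitrogen, gives 25200 nM in this assay, and a 1.2-fold higher number from compound 2 to compound 3 (0.07 log units; within the scatter) lies within the scatter. Compound 1 `O=C1C[C@H](OCc2cn(Cc3ccccc3)nn2)[C@H]2CO[C@@H]1O2` gives > 50000 nM in this assay, which is a limit rather than a number. The step of an at least 2.3-fold lower number from compound 1 to compound 2 (0.37 log units; beyond the scatter) is the one measured move onto methoxycarbonyl.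

Compound 4 `C=C(C)Cn1cc(CO[C@H]2CC(=O)[C@@H]3OC[C@H]2O3)nn1` differs from compound 2 by 1-methylethenyl in place of methoxycarbonyl on a saturated chain carbon bound to an aromatic nitrogen. The change removes the methoxycarbonyl whose arrival in an at least 2.3-fold lower number from compound 1 to compound 2 (0.37 log units; beyond the scatter) went with a lower number. The benzyl of compound 1 sits at the limit of > 50000 nM in this assay, at which 1 of the 3 values shown sits. A modest move to a higher number is therefore expected for compound 4, with a real chance that only a limit is returned. Compound 4 is expected to give 40000 nM, between 18000 nM and 90000 nM. The expected step is a 1.9-fold higher number from compound 2 to compound 4 (0.27 log units; within the scatter).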

Compound 4, half-maximal inhibitory concentration: 26700 nM
For compound 4 the middle estimate is 1.5-fold (0.18 log units) above the measured one, within the range that was stated.
By their numbers in this assay, from the lowest: compounds 2, 3 and 4 (each within the scatter of the next). At a limit, above all of these: compound 1.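

With 1-methylethenyl, which carries no hydrogen-bond acceptors, on the saturated chain carbon bound to an aromatic nitrogen, this assay shows a 1.3-fold higher number from compound 2 to compound 4 (0.10 log units; within the scatter), so the methoxycarbonyl of compound 2 is not needed to hold this level. The read against the aromatic group is a 1.1-fold higher number from compound 3 to compound 4 (0.03 log units; within the scatter), and (methoxycarbonyl)methyl, phenyl and 2-methylprop-2-en-1-yl on the aromatic nitrogen therefore do not separate in compounds 2, 3 and 4. Compound 1 alone stays at a limit, and the comparison with it gives only a floor in an at least 1.8-fold lower number from compound 1 to compound 4 (0.27 log units; that floor lies within the scatter): the limit of > 50000 nM in this assay, at which 1 of the 4 values shown sits.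

As far as these compounds go, whether an amine or a carboxylic acid on that chain carbon, or a longer chain, would move the number beyond the scatter from compound 2 remains open. Also open, from the compounds shown here alone, is whether the benzyl of compound 1 truly differs from the other groups, since its value is a limit.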